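Pyrazolylamide series: quinolinyl to bromophenyl amide

The source may report more compounds than this note shows. Statements on the series, on what has been measured and on what is new or still open speak of the compounds shown alone.

Measured compounds:
compound 1 `CC1(C)c2[nH]nc(NC(=O)c3ccccc3)c2CN1Cc1cc(F)ccc1F` 480 nM
compound 2 `Cc1ccc(CN2Cc3c(NC(=O)c4ccccc4)n[nH]c3C2(C)C)cc1F` 940 nM
compound 3 `CC1(C)c2[nH]nc(NC(=O)c3ccc4ncccc4c3)c2CN1Cc1cc(F)cc(F)c1` 180 nM

All three were read in an assay on Sf21 cells for inhibition of high affinity nerve growth factor receptor (Homo sapiens), read by HTRF, with a stated time of 30 min, in the presence of a further agent that is not named here; on this read-out higher numbers stand for weaker inhibition and lower numbers for stronger inhibition. Compound 3 stands at the lowest number of the three; compound 1 and compound 2 both sit at higher numbers, each beyond the scatter. Within the data shown here, the one measured single-point step, a 2.0-fold higher number from compound 1 to compound 2 (0.29 log units; within the scatter), concerns the benzyl side and lies within the scatter.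

Compound 4 `CC1(C)c2[nH]nc(NC(=O)c3ccc(Br)cc3)c2CN1Cc1cc(F)cc(F)c1` is not yet measured. It differs from compound 3 at the amide end: 4-bromophenyl in place of quinolin-6-yl on a carbonyl carbon. Among the measured compounds shown here, no measured pair bears directly on this change. The only indirect bearing is that compound 1 and compound 2 carry an unsubstituted phenyl on that carbonyl carbon: compound 1 gives 480 nM and compound 2 gives 940 nM, both higher numbers than compound 3, though they also differ from compound 3 on the benzyl side. A moderately higher number is therefore expected for compound 4, estimated as a 2.2-fold higher number from compound 3 to compound 4 (0.35 log units; beyond the scatter). Compound 4 is expected at about 400 nM, within 150 nM to 1200 nM.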

Compound 4, half-maximal inhibitory concentration: 710 nM
Compound 4: middle estimate off by 1.8-fold (0.25 log units), on the low side; the measured number falls inside the stated range.
By their numbers in this assay, from the lowest: compound 3; then compounds 1, 4 and 2 (each within the scatter of the next).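

In this assay, the carbonyl end proves responsive: a 3.9-fold higher number from compound 3 to compound 4 (0.60 log units; beyond the scatter), a change beyond the scatter with the benzyl side held constant, whereas the earlier benzyl-side step, a 2.0-fold higher number from compound 1 to compound 2 (0.29 log units; within the scatter), lay within it. Among these compounds, this is the first direct reading at this position, and quinolin-6-yl is favoured over 4-bromophenyl on this carbonyl carbon in this matched pair. The change removes the second aromatic ring and the ring nitrogen and introduces bromine all at once, and no accompanying data bear on why the number moves.

The compounds shown leave open which of these differences carries the step. A naphthyl group on the same carbonyl carbon would keep both rings without the ring nitrogen, while a pyridyl group would keep the ring nitrogen without the second ring.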